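A few compounds are considered here, and "the series" means these few. Any claim that something is new, unique, unknown or untested is made for them only; others in the source may bear on it.

Compound 1 `O=C1NC(C(=O)NCCCO)CCCCCCC1CS`: 209 nM
Compound 2 `O=C1NC(C(=O)NCCOCCO)CCCCCCC1CS`: 84 nM

The two measured compounds share one core and differ only in the group on a saturated chain carbon, two bonds along the chain from an amide-type nitrogen. In an assay on kidney for inhibition of Neprilysin (Rattus norvegicus) (a higher number here means a weaker inhibitor, a lower number a stronger inhibitor), compound 1 gives 209 nM, the higher of the two numbers. Among the measured compounds shown here, compound 2 gives 84 nM, so the one measured step is a 2.5-fold lower number from compound 1 to compound 2 (0.40 log units; beyond the scatter), a modest change that lies beyond the scatter.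

Compound 3 `CS(=O)(=O)CCCNC(=O)C1CCCCCCC(CS)C(=O)N1` differs from compound 1 in a different way: methylsulfonyl in place of hydroxy on a saturated chain carbon, three bonds along the chain from an amide-type nitrogen. For the measured compounds named here, no measured pair shows a hydroxy group giving way to a methylsulfonyl group, so nothing bears on this change directly. Going by the values given here, the step from compound 1 to compound 2 shows only that altering the group carried on this side chain moves the number modestly, and in that case toward a lower value. Without a closer precedent, he expects compound 3 to stay near compound 1, with a step of a 1.3-fold lower number from compound 1 to compound 3 (0.12 log units; within the scatter) that is not beyond the scatter. His estimate for compound 3 is therefore 160 nM, with a range from 50 nM to 500 nM.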

Compound 3, half-maximal inhibitory concentration: 63 nM
Estimate against measurement, compound 3: 2.5-fold (0.40 log units) above; the measured number falls inside the stated range.
By their numbers in this assay, from the lowest: compounds 3 and 2 (each within the scatter of the next); then compound 1.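

In this assay the change from hydroxy to methylsulfonyl gives a 3.3-fold lower number from compound 1 to compound 3 (0.52 log units; beyond the scatter) and so shows that, on a saturated chain carbon, three bonds along the chain from an amide-type nitrogen, the hydroxy group and its hydrogen-bond donor can leave without the number rising. The comparison with the other improved compound gives a 1.3-fold lower number from compound 2 to compound 3 (0.12 log units; within the scatter) and so shows that two different side-chain ends reach the same level, one keeping a terminal hydroxy in its 2-hydroxyethoxy group and the other, the 3-(methylsulfonyl)propyl chain, carrying none. No measurement bears on why the number moves with this change.

The compounds shown leave open whether the lower number is particular to the methylsulfonyl group or would also come with another group at the end of the same chain, such as a carboxylic acid, an amine or an unsubstituted sulfonamide. They also leave open whether methylsulfonyl would keep this level on a shorter chain, as in 2-(methylsulfonyl)ethyl, or on a longer one such as 4-(methylsulfonyl)butyl.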